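Three Trypsin Limits and a Fourth Compound to Come

A few compounds are considered here, and "the series" means these few. Any claim that something is new, unique, unknown or untested is made for them only; others in the source may bear on it.

compound 1 `Cc1nn(-c2cccc(CN)c2)c2cc(-c3ccc(N4CCCC4=O)cc3)ccc12` — > 10000 nM
compound 2 `Nc1noc2ccc(-n3nc(C(F)(F)F)c4ccc(-c5ccc(N6CCCCC6=O)cc5F)c(F)c43)cc12` — > 10000 nM
compound 3 `CN(C)Cc1[nH]ncc1-c1ccc(-c2ccc3c(C(N)=O)nn(-c4ccc5onc(N)c5c4)c3c2F)c(F)c1` — > 10000 nM

All three were tested in an assay on isolated protein for inhibition of Trypsin (Homo sapiens); on this read-out higher numbers stand for weaker inhibition and lower numbers for stronger inhibition. For compound 3 the value is a limit of the assay, not a number. The same holds for compound 1. It holds for compound 2 as well. Compound 3 therefore sits at the limit of > 10000 nM in this assay, at which 3 of the 3 values shown sit, with no ranking among the three possible.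

Compound 4 `CN(C)CCN(c1ccccc1)c1ccc(-c2ccc3c(C(N)=O)nn(-c4ccc5onc(N)c5c4)c3c2F)c(F)c1` differs from compound 3 by (2-(dimethylamino)ethyl)(phenyl)amino in place of 5-((dimethylamino)methyl)-1H-pyrazol-4-yl on an aromatic carbon. Going by the values given here, no step between measured compounds is available, so no size can be read off; nothing beyond the scatter is expected in this assay. Compound 4 is expected to give 20000 nM, between 8000 nM and 100000 nM. The expected step that the limit leaves unreadable from compound 3 to compound 4 is small or none.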

Compound 4, inhibition constant: > 10000 nM
Compound 4 was reported as a limit; the forecaster's own chance of this, stated with the estimate: 85%; the middle value does not contradict the limit.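

No step can be read from compound 3 to compound 4 in this assay, since both values are limits of the assay: the limit of > 10000 nM in this assay, at which 4 of the 4 values shown sit.

The compounds shown leave open how these four compounds rank against one another.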